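Ester of the acid series: expectation for compound 4

This account rests on a few compounds, and the source may have more. Where it says the series, first, only, none or still open, it means among the compounds named here.

Measured so far:
compound 1 `C=CC(=O)Nc1ccc(Cn2nc(-c3ccc(Oc4ccccc4)cc3)cc2C(=O)O)cc1`: > 60000 nM
compound 2 `C/C=C/C(=O)Nc1ccc(Cn2nc(-c3ccc(Oc4ccccc4)cc3)cc2C(=O)O)cc1`: > 60000 nM
compound 3 `C/C=C/C(=O)Nc1cccc(Cn2nc(-c3ccc(Oc4ccccc4)cc3)cc2C(=O)O)c1`: 31600 nM

In a functional assay on Maver1 cells (Homo sapiens) for inhibition, read by luminescence and CellTiter-Glo, with a stated time of 72 h (a lower number here means a stronger inhibitor, a higher number a weaker inhibitor), compound 1 returns only a limit, > 60000 nM, and not a number. Compound 2 likewise returns only a limit, > 60000 nM. Compound 3 gives a number, 31600 nM. Compound 1 therefore stands at the weak end of what this assay can report, on (the limit of > 60000 nM in this assay, at which 2 of the 3 values shown sit). Within the data shown here, the single step between measured neighbours, a step that the two limits leave unreadable from compound 1 to compound 2, cannot be read because both ends are limits.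

The unmeasured compound 4 `C=CC(=O)Nc1ccc(Cn2nc(-c3ccc(Oc4ccccc4)cc3)cc2C(=O)OCC)cc1` differs from compound 1 by ethyl in place of hydrogen on an oxygen next to a carbonyl group. Among the measured compounds shown here, no measured step touches the carboxylic acid; the only change examined so far sits on the amide side, and that step is unreadable. For the measured compounds named here, the step from compound 1 to compound 4 in this assay thus has no precedent among the measured pairs, and no direction can be taken from them.

With compound 1 at a limit, the estimate for compound 4 is 45000 nM, within 12000 nM to 120000 nM; this corresponds to an expected step of an at least 1.3-fold lower number from compound 1 to compound 4 (0.12 log units; that floor lies within the scatter), treated as no change beyond the scatter and with a substantial chance that compound 4 again returns only a limit.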

Compound 4, half-maximal inhibitory concentration: 13300 nM
For compound 4 the middle estimate is 3.4-fold (0.53 log units) above the measured one, within the range that was stated.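

In this assay, among these compounds, the change from carboxy to ethoxycarbonyl gives the first readable step, an at least 4.5-fold lower number from compound 1 to compound 4 (0.65 log units; beyond the scatter), so the oxygen next to the carbonyl group is a place where a change moves the read-out. That size is a floor and not a measured gap, since the carboxylic acid end of the pair stands at a limit: the limit of > 60000 nM in this assay, at which 2 of the 4 values shown sit. Among the compounds shown here, the only earlier step, on the amide side, cannot be read, which makes this the sole substitution so far with a visible direction, and it rests on a single pair.

Open, going by these compounds, is whether the step belongs to ethyl in particular or would also follow from a methyl ester, a longer chain on the same oxygen, or a primary amide in place of the carboxylic acid. Also open, on these data alone, is whether ethoxycarbonyl gives a step of similar direction on the cores of compound 2 and compound 3, where the amide side differs, and whether the amide side can be read at all once the carboxylic acid is replaced.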